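Removing an Amino Group: Expected Effect on Cell Toxicity

The compounds below may be only part of what the source reports. "The series", "measured", "known", "first", "only" and "open" are said of these compounds alone.

Of the compounds shown here, three built on one shared core have been tested in an ADME assay on MDBK cells (Bos taurus) for cytotoxicity, read by MTT assay, with a stated time of 96 h; on this read-out lower numbers stand for higher toxicity in this test and higher numbers for lower toxicity in this test. Compound 1 `Fc1ccc(-c2nc3cc(C(F)(F)F)ccc3[nH]2)cc1` gives 19000 nM. Compound 2 `COc1ccc(-c2nc3cc(Cl)c(Cl)cc3[nH]2)c(N)c1` gives 6500 nM, the lowest of the two numbers recorded, so it is the more toxic of these two; the number for compound 1 lies higher by a gap that is beyond the usual scatter of repeated measurements. Compound 3 `Fc1cccc(F)c1-c1nc2cc(C(F)(F)F)ccc2[nH]1` sits at the limit of >= 100000 nM in this assay, at which 1 of the 3 values shown sits, and its result of >= 100000 nM is a limit of the assay rather than a number.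

Compound 4 `COc1ccc(-c2nc3cc(Cl)c(Cl)cc3[nH]2)cc1` has not yet been measured in this assay. It differs from compound 2 in one place: hydrogen in place of amino on an aromatic carbon. Going by the values given here, no measured pair in this set shows the same change, so the expectation rests on compound 2 alone, whose value of 6500 nM is the starting point. Compound 4 is expected to give 12000 nM, with a plausible range from 3000 nM to 50000 nM. This estimate means a step of a 1.8-fold higher number from compound 2 to compound 4 (0.27 log units; within the scatter), expected to lie within the usual scatter, with a modest lean toward a higher number, which in this assay would mean slightly lower toxicity.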

Compound 4, half-maximal cytotoxic concentration: 2500 nM
For compound 4 the middle estimate is 4.8-fold (0.68 log units) above the measured one; the measured number lies below the stated range.
By their numbers in this assay, from the lowest: compound 4; then compound 2; then compound 1. At a limit, above all of these: compound 3.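

In this assay, replacing the amino group with hydrogen gives a 2.6-fold lower number from compound 2 to compound 4 (0.41 log units; beyond the scatter), and on this read-out a lower number means higher toxicity in this test. Going by these compounds alone, as the only pair here that differs in one place, it shows that this aromatic carbon, ortho to a large group and meta to a methoxy group, is a place where a single change can move the value beyond the usual scatter, and that losing the amino group goes with more toxicity in this test, not less. Nothing measured in this set bears on why the value moves this way, so the reason stays unknown.

As far as these compounds go, this is a single pair, so it remains open whether the same change would shift the value in the same direction on a differently substituted version of the shared core. From the compounds shown here alone, it also remains open what a hydroxyl group, a methyl group or a longer amine on this same aromatic carbon would give, and so whether the effect belongs to the amino group itself or would appear with other groups there.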